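Configuration Change in a Peroxide Ester Cytotoxicity Series

The source may report more compounds than this note shows. Statements on the series, on what has been measured and on what is new or still open speak of the compounds shown alone.

Compound 1 `COC(=O)[C@H](C)[C@H]1CC[C@@](C)(CCC2=C(C)C(=O)CCC2(C)C)OO1`: in a functional assay on L5178Y cells (Mus musculus) for cytotoxicity, read by MTT assay (on this read-out higher numbers stand for an effect only at larger amounts of compound and lower numbers for an effect already at smaller amounts), compound 1 gives only a limit of the assay, > 10 ug/mL.
Compound 2 `COC(=O)[C@@H](C)[C@@H]1CC[C@](C)(CCC(=O)C(C)(C)CCCC(C)=O)OO1`: in this assay compound 2 gives 10 ug/mL.

Compound 2 carries the only number shown; the other value is the limit of > 10 ug/mL in this assay, at which 1 of the 2 values shown sits, belonging to compound 1. Compound 3 `COC(=O)[C@H](C)[C@@H]1CC[C@@](C)(CCC(=O)C(C)(C)CCCC(C)=O)OO1` differs from compound 2 as follows: the two compounds have the same atoms and bonds and differ only in configuration as drawn: 2 of 3 stereo elements differ; a stereocentre at a saturated chain carbon is drawn S in compound 2 and R in compound 3; a stereocentre at a saturated ring carbon is drawn R in compound 2 and S in compound 3. Within the data shown here, no measured pair in this set differs in one place, so nothing shows how such a change moves the read-out. Compound 3 is expected to stay near compound 2, with an expected step of no change at the digits printed from compound 2 to compound 3 (within the scatter) no larger than the usual scatter. The estimate for compound 3 in this assay is 10 ug/mL, between 4 ug/mL and 25 ug/mL.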

Compound 3, half-maximal effective concentration: > 10 ug/mL
Compound 3 gave a limit, no number; the forecaster's own chance of this, stated with the estimate: 45%; the middle value lies on the limit itself.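

In this assay, the change of configuration at the saturated chain carbon and the saturated ring carbon gives a number no lower from compound 2 to compound 3 (the limit leaves the size open). Compound 3 gives only a limit, > 10 ug/mL. This is the one step in the set that can be read for direction, and it shows no shift toward effect at smaller amounts, with the comparison resting on configuration alone: the fact that compounds 2 and 3 differ only in the configuration as drawn

As far as these compounds go, the size of the step stays open, as does whether either stereocentre alone would account for it. Also open, from the compounds shown here alone, is how the read-out would respond if a carboxylic acid replaced the methyl ester.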